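This account rests on a few compounds, and the source may have more. Where it says the series, first, only, none or still open, it means among the compounds named here.

In an ADME assay on HEK-293T cells (Homo sapiens) for cytotoxicity, read by CCK-8 assay, with a stated time of 48 h (on this read-out higher numbers stand for weaker inhibition and lower numbers for stronger inhibition), compound 2 `O=S(=O)(NCCNC(=S)Nc1cccc(Cl)c1)c1ccc(-c2ccccc2OCc2ccccc2)s1` gives 10200 nM while compound 1 `O=S(=O)(NCCNC(=S)Nc1cccc(Cl)c1)c1ccc(-c2ccccc2OCc2cccc(O)c2)s1` gives 17400 nM and compound 3 `O=C(NCCNS(=O)(=O)c1ccc(-c2ccccc2Oc2ccc(O)c(O)c2)s1)Nc1cc(Cl)cc(Cl)c1` gives 12400 nM so all three sit within the usual scatter of one another. Compound 4 `O=C(NCCNS(=O)(=O)c1ccc(-c2ccccc2OCc2ccccc2)s1)Nc1cccc([N+](=O)[O-])c1` differs from compound 2 in one place: a group of 12 heavy atoms (7 carbon, 2 nitrogen, 3 oxygen; one six-membered aromatic ring of carbon only) in place of a group of 10 heavy atoms (7 carbon, 1 nitrogen, 1 sulfur, 1 chlorine; one six-membered aromatic ring of carbon only), on an amine nitrogen where (3-nitrophenyl)carbamoyl enters on an amine nitrogen. Going by the values given here, no measured pair tests this exchange directly. Resting on the one measured step of a 1.7-fold lower number from compound 1 to compound 2 (0.23 log units; within the scatter) which is a different change (hydrogen in place of hydroxy on an aromatic carbon) and stays within the scatter, no step beyond the scatter is expected in this assay here either. That means an estimated 1.1-fold higher number from compound 2 to compound 4 (0.03 log units; within the scatter) (within the scatter). For compound 4 the expected value is 11000 nM (range 5000 nM to 25000 nM).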

Compound 4, half-maximal inhibitory concentration: 13300 nM
Compound 4: the middle estimate sits 1.2-fold (0.08 log units) below what was measured; the range from low to high includes it.
By their numbers in this assay, from the lowest: compounds 2, 3, 4 and 1 (each within the scatter of the next).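

On the amine nitrogen, the change from the group in compound 2 to (3-nitrophenyl)carbamoyl gives a 1.3-fold higher number from compound 2 to compound 4 (0.12 log units; within the scatter) in this assay and so is the first exchange shown at this position. The swap removes the sulfur and chlorine of the leaving group and brings in more hydrogen-bond acceptors, yet the step stays within the scatter. From the compounds shown here alone, whether a group without an aromatic ring, such as a simple acetyl or a basic amine, would also leave the number unmoved remains open. No measured evidence here explains the result.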